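A few compounds are considered here, and "the series" means these few. Any claim that something is new, unique, unknown or untested is made for them only; others in the source may bear on it.

Two compounds share a core in which a cyclopropyl-bearing nitrogen is attached to a purine-type scaffold and carries an acetamide arm to an amino acid benzyl ester. Compound 1, `CC[C@H](C)[C@H](NC(=O)CN(c1ncnc2c1ncn2C1CCCCO1)C1CC1)C(=O)OCc1ccccc1`, is the one with the sec-butyl side chain and a tetrahydropyranyl group on the core. In a functional assay on the whole organism (Tail, strain ICR) with Mus musculus as the target, in the tail flick test, with a stated time of 90 min, at a dose of 25 umol/kg by the oral route (a higher number here means a stronger effect of the compound at the dose given, a lower number a weaker effect), compound 1 gives 22.6%, the lower of the two numbers measured. Compound 2, `CC[C@H](C)[C@H](NC(=O)CN(c1nc(Cl)nc2[nH]cnc12)C1CC1)C(=O)OCc1ccccc1`, differs from it in more than one place, with a chlorine on the core and a free ring nitrogen-hydrogen, and in this assay compound 2 gives 36.3%, a number that lies beyond the usual scatter above compound 1.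

Compound 3, `O=C(CN(c1ncnc2c1ncn2C1CCCCO1)C1CC1)N[C@@H](CC(=O)OCc1ccccc1)C(=O)OCc1ccccc1`, keeps the core and the tetrahydropyranyl group of compound 1 and changes only the side chain: (benzyloxycarbonyl)methyl in place of sec-butyl on a saturated chain carbon bound to an amide-type nitrogen and a carbonyl carbon. Among the measured compounds shown here, no measured pair in this set isolates such a change, so its effect is unknown from the data. Given that compound 1 stands at 22.6% and that compound 2 differs elsewhere, no direction can be read off. Compound 3 is therefore expected to stay close to compound 1, with an expected step of a number 2.6 percentage points lower from compound 1 to compound 3 (within the scatter) that lies within the scatter. The estimate for compound 3 in this assay is 20%, with a range from 5% to 38%.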

Compound 3, a percentage reported as activity, at one dose (the size of the read-out at that dose, not a potency): 25.1%
Compound 3: middle estimate off by 5.1 percentage points, on the low side, within the range that was stated.
By their numbers in this assay, from the lowest: compounds 1 and 3 (each within the scatter of the next); then compound 2.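

In this assay, among the compounds shown here, the change of side chain alone gives a number 2.5 percentage points higher from compound 1 to compound 3 (within the scatter) and is the first step in this set that isolates a single position. On the core of compound 1 with its tetrahydropyranyl group, the read-out at this one dose therefore does not separate a sec-butyl group of 4 heavy atoms and no ring from a group of 11 heavy atoms that brings a six-membered aromatic ring and 2 hydrogen-bond acceptors. The data available offer no measurement that would account for this result.

On these data alone, whether a carboxylic acid at the end of this side chain, or an amine on a longer chain, would also stay within the scatter of compound 1 remains open. As far as these compounds go, it is also open whether the same replacement would behave alike on the core of compound 2, with its chlorine and free ring nitrogen-hydrogen, and whether a single-dose read-out hides differences that other doses would reveal.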